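The compounds below may be only part of what the source reports. "The series", "measured", "known", "first", "only" and "open" are said of these compounds alone.

Of the compounds shown here, two have been tested in a functional assay on HeLa cells (Homo sapiens) for cytotoxicity, read by WST assay, with a stated time of 48 h; a higher number here means a weaker inhibitor, a lower number a stronger inhibitor. Compound 1, `COc1ccc(/C=C/C[C@H]2C[C@H]([C@H](O)c3ccc(OC)c(OC)c3)CO[C@@H]2c2ccc(OC)c(OC)c2)cc1OC`, carries methoxy groups on each of its three aromatic rings; in this assay compound 1 gives 34600 nM. Compound 2, `Oc1ccccc1/C=C/C[C@H]1C[C@@H]([C@@H](O)c2ccccc2)CO[C@@H]1c1ccccc1`, has a single hydroxyl on the ring at the end of its side chain and bare phenyl rings elsewhere; in this assay compound 2 gives 21800 nM. The two numbers sit within the usual scatter of each other, so nothing separates compound 2 from compound 1 on what has been measured.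

The next compound, compound 3, `Oc1cccc(/C=C/C[C@H]2C[C@@H]([C@@H](O)c3ccccc3)CO[C@@H]2c2ccccc2)c1`, is built from the same atoms as compound 2, joined differently: 3-hydroxyphenyl in place of 2-hydroxyphenyl on a double-bonded chain carbon bound to a double-bonded chain carbon. Among the measured compounds shown here, no measured pair shows what shifting the hydroxyl in this way does, so the expectation rests on compound 2 alone. Since the hydroxyl stays on the same ring and the rest is unchanged, the expected step of a 1.0-fold higher number from compound 2 to compound 3 (0.00 log units; within the scatter) is none beyond the scatter, in either direction. Compound 3 is therefore estimated at 22000 nM, with a range from 8000 nM to 60000 nM.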

Compound 3, half-maximal inhibitory concentration: 18600 nM
Compound 3: middle estimate off by 1.2-fold (0.07 log units), on the high side; low and high end bracket the measured number.
By their numbers in this assay, from the lowest: compounds 3, 2 and 1 (each within the scatter of the next).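

Among the compounds shown here, replacing 2-hydroxyphenyl with 3-hydroxyphenyl gives the first comparison that changes only one place, and in this assay it reads a 1.2-fold lower number from compound 2 to compound 3 (0.07 log units; within the scatter). On this evidence, moving the hydroxyl between these two ring positions, on a double-bonded chain carbon bound to a double-bonded chain carbon, does not separate the two compounds, something that compound 1 and compound 2 could not show because they differ in several places at once. Nothing available here offers an explanation for this result.

The compounds shown leave open whether a different group on this ring, such as an amine or a carboxylic acid in place of the hydroxyl, would give a step beyond the scatter, and whether a longer chain leading to the ring would do so. For the compounds shown here, it also remains open what each methoxy group of compound 1 contributes on its own, since no single-place step connects compound 1 to compound 2 or compound 3.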